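Chloro in Place of Methoxy on the Phenyl Ring

The source may hold more compounds than are shown below. What is called first, only, known or untested is meant among the compounds shown, and "the series" means these compounds.

Of the compounds shown here, two on a shared core have been measured. Compound 1 `CC1(C)[C@H]2CC[C@]1(C)N(Cc1cn(-c3ccc(Cl)cc3)nn1)C(=O)C2` gives 440 nM in a functional assay on PANC-1 cells (Homo sapiens) for inhibition, read by MTT assay, with a stated time of 24 h; on this read-out lower numbers stand for stronger inhibition and higher numbers for weaker inhibition. Compound 2 `COc1ccccc1-n1cc(CN2C(=O)C[C@@H]3CC[C@@]2(C)C3(C)C)nn1` gives 120 nM in this assay, the lowest of the two numbers, with compound 1 as its nearest neighbour; the step of a 3.7-fold lower number from compound 1 to compound 2 (0.56 log units; beyond the scatter) came with 2-methoxyphenyl in place of 4-chlorophenyl on an aromatic nitrogen. Compound 3 `CC1(C)[C@H]2CC[C@]1(C)N(Cc1cn(-c3ccccc3Cl)nn1)C(=O)C2` is not yet measured. It differs from compound 2 by chloro in place of methoxy on an aromatic carbon, the phenyl ring reading 2-chlorophenyl rather than 2-methoxyphenyl. Going by the values given here, only the step from compound 1 to compound 2 bears on this, and it exchanged 4-chlorophenyl for 2-methoxyphenyl, not methoxy for chloro alone, so it is a rough guide. Compound 3 is therefore expected to fall between its two neighbours, with a modest rise of a 2.1-fold higher number from compound 2 to compound 3 (0.32 log units; beyond the scatter). In this assay compound 3 is estimated at 250 nM, within a range from 100 nM to 600 nM.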

Compound 3, half-maximal inhibitory concentration: 270 nM
The estimate for compound 3 lay 1.1-fold (0.03 log units) below the measured number; measured number inside the range.
By their numbers in this assay, from the lowest: compound 2; then compounds 3 and 1 (each within the scatter of the next).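

Compound 3 pulls apart the two changes joined in the earlier step. In this assay, chloro in place of methoxy on an aromatic carbon, ortho to a large group, gives a 2.3-fold higher number from compound 2 to compound 3 (0.35 log units; beyond the scatter), so at this place the methoxy compound holds the lower number by more than the scatter. Exchanging 4-chlorophenyl for 2-chlorophenyl gives a 1.6-fold lower number from compound 1 to compound 3 (0.21 log units; within the scatter), which does not separate the two chloro compounds, and nothing at hand explains either step.

Open, from the compounds shown here alone, is whether another group at this place, such as an amine, a hydroxyl or a longer chain like ethoxy, would match the number given by methoxy. Also open, going by these compounds, is whether 4-methoxyphenyl would read like 2-methoxyphenyl.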